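Chloro to trifluoromethyl on an imidazoline sulfone scaffold

The source may hold more compounds than are shown below. What is called first, only, known or untested is meant among the compounds shown, and "the series" means these compounds.

Compound 1 `COc1ccc(S(C)(=O)=O)c(NCC2=NCCN2)c1`: 7590 nM
Compound 2 `CS(=O)(=O)c1ccc(Cl)cc1NCC1=NCCN1`: 2400 nM

Among the compounds with values here, in an assay for binding affinity to Alpha-1D adrenergic receptor (Homo sapiens), read by radioligand binding (a higher number here means a weaker inhibitor, a lower number a stronger inhibitor), compound 2 gives the lower of the two numbers measured so far, and the measured step is a 3.2-fold lower number from compound 1 to compound 2 (0.50 log units; beyond the scatter). Compound 3 `CS(=O)(=O)c1ccc(C(F)(F)F)cc1NCC1=NCCN1` differs from compound 2 by trifluoromethyl in place of chloro on an aromatic carbon. Within the data shown here, no measured step swaps chloro for trifluoromethyl; the one known step, from methoxy to chloro at the same place, was modest. So only a modest change in this assay is expected, direction uncertain, and the step from compound 2 to compound 3 is estimated as a 1.2-fold lower number from compound 2 to compound 3 (0.08 log units; within the scatter). For compound 3 the expected value is 2000 nM, between 700 nM and 6000 nM.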

Compound 3, inhibition constant: < 15900 nM
Compound 3 ended at the assay's limit; the forecaster's own chance of this, stated with the estimate: 5%; the middle value does not contradict the limit.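

In this assay compound 3 gives < 15900 nM, which is a limit of the assay and not a number. The steps to compound 3 from compound 1 and compound 2 therefore cannot be read: the limit of < 15900 nM in this assay, at which 1 of the 3 values shown sits.

On these data alone, whether trifluoromethyl in place of chloro gives a higher or a lower number stays open.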